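From an Inactive Methoxyphenyl Analogue to a Dichlorophenyl One

The compounds below may be only part of what the source reports. "The series", "measured", "known", "first", "only" and "open" are said of these compounds alone.

The compounds share one core and differ only in the aromatic group attached to the amine nitrogen in a ring. Compound 1, `CC1(c2ccccc2)CC(=O)N(CC(=O)N2CCN(c3ccccc3Cl)CC2)C1=O`, gives "not active" (no number reported) in a functional assay on the whole organism (strain CD-1) with Mus musculus as the target, in the maximal electroshock model, with a stated time of 2 h; a lower number here means that less compound is needed, a higher number that more compound is needed for the effect. Compound 2, `CC1(c2ccccc2)CC(=O)N(CC(=O)N2CCN(c3ccc(F)cc3)CC2)C1=O`, gives 100 mg/kg in this assay. Compound 3, `COc1cccc(N2CCN(C(=O)CN3C(=O)CC(C)(c4ccccc4)C3=O)CC2)c1`, gives "not active" (no number reported) in this assay; for it no single number was reported, and one further compound, compound 1, also stands without a single number, so compound 3 cannot be placed against compound 2 on a scale.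

Compound 4, `CC1(c2ccccc2)CC(=O)N(CC(=O)N2CCN(c3cccc(Cl)c3Cl)CC2)C1=O`, has not yet been tested. It differs from compound 3 as follows: 2,3-dichlorophenyl in place of 3-methoxyphenyl on an amine nitrogen in a ring. Within the data shown here, no measured pair shows this change, so the size of the step cannot be read from the data. Given that compound 3 gives "not active" (no number reported) and compound 1 gives "not active" (no number reported), while only compound 2 with 100 mg/kg shows a number at all, compound 4 is expected most likely to remain inactive, or to need a high dose if any effect appears. The estimate for compound 4 in this assay is 300 mg/kg, within a range from 100 mg/kg to 1000 mg/kg.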

Compound 4, minimum effective dose: "not active" (no number reported)
Nothing numeric was reported for compound 4; the estimate stays without a comparison.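

In this assay, among these compounds, compound 4 gives "not active" (no number reported) and compound 3 gives "not active" (no number reported), and no step between them can be read. No supporting evidence bears on this result. Left open is how the aromatic group changes the dose needed: only compound 2 has a number, 100 mg/kg.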